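Compound 2 and an untested relative

The compounds below may be only part of what the source reports. "The series", "measured", "known", "first", "only" and "open" are said of these compounds alone.

Compound 1 `O=S(=O)(/C=C/c1ccc(Cl)cc1Cl)Cc1ccc(Nc2ncnc3ccc(Br)cc23)cc1`: > 100000 nM, a limit and not a number
Compound 2 `O=S(=O)(/C=C/c1ccc(C(F)(F)F)cc1F)Cc1ccc(Nc2ncnc3ccc(Br)cc23)cc1`: 85000 nM
Compound 3 `O=S(=O)(/C=C/c1ccc(F)cc1F)Cc1ccc(Nc2ncnc3ccc(Br)cc23)cc1`: 100000 nM

These three compounds were read in a functional assay on NCI/ADR-RES cells (Homo sapiens) for inhibition; on this read-out higher numbers stand for weaker inhibition of growth and lower numbers for stronger inhibition of growth. Only two of them carry a number, and those two lie close together: a 1.2-fold higher number from compound 2 to compound 3 (0.07 log units; within the scatter). Compound 1 stands at a limit of this assay, so its steps are bounded rather than sized: an at least 1.1-fold lower number from compound 1 to compound 2 (0.07 log units; that floor lies within the scatter), and a number no higher from compound 1 to compound 3 (the limit leaves the size open).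

Compound 4 `O=S(=O)(/C=C/c1ccc(C(F)(F)F)cc1F)Cc1ccc(Nc2ncnc3cc(Cl)ccc23)cc1` has not yet been measured. It differs from compound 2 in the group on a nitrogen on an aromatic ring, where 7-chloroquinazolin-4-yl enters: a group of 11 heavy atoms (8 carbon, 2 nitrogen, 1 chlorine; one six-membered aromatic ring of carbon only, one six-membered aromatic ring with 2 hetero atoms) in place of a group of 11 heavy atoms (8 carbon, 2 nitrogen, 1 bromine; one six-membered aromatic ring of carbon only, one six-membered aromatic ring with 2 hetero atoms), on a nitrogen on an aromatic ring. All three measured steps change a different part of the molecule, and the group exchanged here stays the same across them. None of them therefore gives a size for this exchange, and the data offer no direct guide to its direction. With compound 2 at 85000 nM as the starting point, no step beyond the scatter is expected in this assay. The expected step is a 1.4-fold lower number from compound 2 to compound 4 (0.15 log units; within the scatter). Compound 4 is estimated at 60000 nM, with an expected range of 15000 nM to 100000 nM.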

Compound 4, concentration for 50% growth inhibition: > 100000 nM
Compound 4: only a limit was reported (the forecaster's own chance of this, stated with the estimate: 35%); middle value at least 1.6-fold (0.22 log units) from the limit.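

Until now, every step had changed the aryl group on the double-bonded chain carbon, and none had touched the group on a nitrogen on an aromatic ring. Among these compounds, the exchange of that group for 7-chloroquinazolin-4-yl, which leaves the counted heavy atoms, hydrogen-bond donors and acceptors unchanged, gives an at least 1.1-fold higher number from compound 2 to compound 4 (0.07 log units; that floor lies within the scatter) in this assay, so the first reading at this place fixes only a floor, and that floor does not separate the exchange from no change at all. The value of compound 4 is a limit and not a number, as is that of compound 1, so the true size of the step stays unread: the limit of > 100000 nM in this assay, at which 2 of the 4 values shown sit.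

The compounds shown leave open how much of this step belongs to the change from bromine to chlorine and how much to any other difference between the two groups, since a single exchange of the whole group cannot be divided. They also leave open whether a methoxy group or an amine on this group, in place of the halogen, would bring a reading in this assay that stands clear of the limit.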